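Removing a Phenyl from the Benzoyl Group

The source may hold more compounds than are shown below. What is called first, only, known or untested is meant among the compounds shown, and "the series" means these compounds.

In a physicochemical assay for solubility, with a stated time of 3 days, at pH 2 (on this read-out higher numbers stand for higher solubility and lower numbers for lower solubility), compound 3 `NC(=O)c1ccc2[nH]c(-c3ccc(OCCC4CCCCN4C(=O)c4ccccc4)cc3)nc2c1` gives 28000 nM and compound 2 `NC(=O)c1ccc2[nH]c(-c3ccc(OCCC4CCCCN4Cc4ccc(Cl)c(Cl)c4)cc3)nc2c1` gives 39000 nM, so the two sit level, with a 1.4-fold lower number from compound 2 to compound 3 (0.14 log units; within the scatter). Compound 1 `NC(=O)c1ccc2[nH]c(-c3ccc(OCCC4CCCCN4Cc4ccccc4)cc3)nc2c1` shows > 400000 nM, which is a limit of the assay and not a number. Compound 4 `CC(=O)N1CCCCC1CCOc1ccc(-c2nc3cc(C(N)=O)ccc3[nH]2)cc1` carries one change, methyl in place of phenyl on a carbonyl carbon, or benzoyl to acetyl. Going by the values given here, no measured step makes this exact change. Two large steps guide it loosely: an at least 10-fold lower number from compound 1 to compound 2 (1.01 log units; beyond the scatter) and an at least 14-fold lower number from compound 1 to compound 3 (1.15 log units; beyond the scatter). Both enlarged the group on the ring nitrogen and lowered the number, so trimming that group should raise it. The expected step is a 5.4-fold higher number from compound 3 to compound 4 (0.73 log units; beyond the scatter). Compound 4 is estimated at 150000 nM, within an expected range of 45000 nM to 400000 nM.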

Compound 4, solubility: > 400000 nM
Compound 4: a limit, no number (the forecaster's own chance of this, stated with the estimate: 20%); at least 2.6-fold (0.42 log units) between middle value and limit.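

In this assay, an acyl group on the ring nitrogen does not by itself bring a low number, since what sits on the carbonyl carbon decides much of the outcome: methyl in place of phenyl gives an at least 14-fold higher number from compound 3 to compound 4 (1.15 log units; beyond the scatter). Acetyl in place of 3,4-dichlorobenzyl on that nitrogen gives an at least 10-fold higher number from compound 2 to compound 4 (1.01 log units; beyond the scatter). Compound 1 and compound 4 cannot be ranked, because each stands at a limit and not at a number: the limit of > 400000 nM in this assay, at which 2 of the 4 values shown sit.

Still open, on these data alone, is how a group between methyl and phenyl behaves on the carbonyl carbon, such as a propyl chain or a cyclopropyl ring.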